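The compounds below may be only part of what the source reports. "The series", "measured", "known", "first", "only" and "open" are said of these compounds alone.

In a functional assay on SK-OV-3 cells (Homo sapiens) for cytotoxicity (a higher number here means a weaker inhibitor of growth, a lower number a stronger inhibitor of growth), compound 1 `COc1ccc(C2=C(c3cc(OC)c(OC)c(OC)c3)CC3CCCN3C2=O)cc1O` gives > 100000 nM, which is a limit of the assay and not a number. Compound 2 `COc1ccc(C2=C(c3ccc(SC)cc3)CC3CCCN3C2=O)cc1O` gives > 100000 nM, again a limit. Among the measured compounds shown here, compound 3 `COc1ccc(C2=C(c3ccc(SC)cc3)CC3CCCN3C2=O)cc1OC(=O)CNC(=O)OC(C)(C)C` gives 20000 nM, the only true number so far, and it is the sole reference point for what follows.

Compound 4 `COc1ccc(C2=C(c3ccc(SC)cc3)CC3CCCN3C2=O)cc1OC(=O)C1CCCN1C(=O)OC(C)(C)C` differs from compound 3 at one place: 1-(tert-butoxycarbonyl)pyrrolidin-2-yl stands in place of ((tert-butoxycarbonyl)amino)methyl on a carbonyl carbon. 1-(tert-butoxycarbonyl)pyrrolidin-2-yl in place of ((tert-butoxycarbonyl)amino)methyl on a carbonyl carbon Both groups carry a tert-butoxycarbonyl unit, and the carbonyl carbon they sit on stays.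

For the measured compounds named here, only one measured step bears on this change: an at least 5.0-fold lower number from compound 2 to compound 3 (0.69 log units; beyond the scatter). That step shows what happened when the hydrogen on the oxygen was replaced. It does not show what happens when one such group is exchanged for another, so it gives no direction for the present swap. Going by the values given here, with no measured step of this kind, the best guess is that compound 4 stays close to compound 3 in this assay, with no shift beyond the scatter. The estimated step is no change at the digits printed from compound 3 to compound 4 (within the scatter), and this is only an expectation. For compound 4 the expected value is 20000 nM, with an estimated range from 6000 nM to 70000 nM.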

Compound 4, concentration for 50% growth inhibition: 10000 nM
Compound 4: the middle estimate sits 2.0-fold (0.30 log units) above what was measured, and the stated range covers the measured number.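

In this assay, among the compounds shown here, the earlier compounds showed only that replacing the hydrogen on the oxygen could give a true number; none exchanged one such group for another. That exchange can now be read, and the step, a 2.0-fold lower number from compound 3 to compound 4 (0.30 log units; within the scatter), puts compound 3 and compound 4 within the usual scatter of each other. On these two compounds alone, the place on the carbonyl carbon accepts 1-(tert-butoxycarbonyl)pyrrolidin-2-yl, with its five-membered non-aromatic ring and 0 hydrogen-bond donors, in place of ((tert-butoxycarbonyl)amino)methyl, with no ring and 1 hydrogen-bond donor, and the number stays within the scatter.

On these data alone, both groups carry the tert-butoxycarbonyl unit, so what that unit contributes remains open; a free amine in its place, or a carboxylic acid or longer chain on the same carbonyl carbon, would test this. Compound 2 is a limit and not a number, so the full size of the gain from adding such a group also remains unknown, because the starting point is only a bound: the limit of > 100000 nM in this assay, at which 2 of the 4 values shown sit.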